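A few compounds are considered here, and "the series" means these few. Any claim that something is new, unique, unknown or untested is made for them only; others in the source may bear on it.

Measured compounds:
- compound 1, `Cc1cc(Nc2nc(NCc3ccc(F)cc3F)nc3ccccc23)n[nH]1`, an assay for inhibition of high affinity nerve growth factor receptor (Homo sapiens), read by HTRF, with a stated time of 30 min, in the presence of a further agent that is not named here; on this read-out higher numbers stand for weaker inhibition and lower numbers for stronger inhibition: 200 nM
- compound 2, `Cc1cc(Nc2nc(NCc3cc(F)ccc3F)nc3ccccc23)n[nH]1`, this assay: 7.5 nM

Among the compounds with values here, compound 2 stands lowest of the two numbers measured so far: the step of a 27-fold lower number from compound 1 to compound 2 (1.43 log units; beyond the scatter) is large and beyond the scatter, so compound 2 is the stronger inhibitor of the pair. Compound 3, `Cc1cc(Nc2nc(NCc3cc(F)cc(F)c3)nc3ccccc23)n[nH]1`, has not been measured. It differs from compound 2 in one place, (3,5-difluorophenyl in place of 2,5-difluorophenyl on a saturated chain carbon bound to a nitrogen on an aromatic ring). Within the data shown here, the only step that bears on this change is the one from compound 1 to compound 2, where moving one fluorine on the same ring changed the number greatly, which shows that the number is very sensitive to where the two fluorines sit. Compound 3 loses a fluorine placement that both measured compounds share, so a step upward is expected for compound 3, roughly a 6.7-fold higher number from compound 2 to compound 3 (0.82 log units; beyond the scatter), with wide uncertainty. The estimate for compound 3 is 50 nM, between 10 nM and 300 nM.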

Compound 3, half-maximal inhibitory concentration: 170 nM
Compound 3: middle estimate off by 3.4-fold (0.53 log units), on the low side; the range from low to high includes it.
By their numbers in this assay, from the lowest: compound 2; then compounds 3 and 1 (each within the scatter of the next).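

In this assay, putting 3,5-difluorophenyl in place of 2,5-difluorophenyl gives a 23-fold higher number from compound 2 to compound 3 (1.36 log units; beyond the scatter) and so the low number of compound 2 does not survive this second rearrangement of the same two fluorines. The comparison of the other two, a 1.2-fold lower number from compound 1 to compound 3 (0.07 log units; within the scatter), leaves 2,4-difluorophenyl and 3,5-difluorophenyl level, so among these three compounds only the 2,5-difluorophenyl group stands apart, even though all three groups contain the same atoms. Nothing available explains why this one arrangement differs.

From the compounds shown here alone, it remains open whether both fluorines are needed for the low number of compound 2, or whether chlorine or a methoxy group could take the place of either one. Also open, going by these compounds, is whether the 2,5-difluorophenyl group would keep that low number on a longer chain.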